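This account rests on a few compounds, and the source may have more. Where it says the series, first, only, none or still open, it means among the compounds named here.

Measured in a functional assay on U-937 cells (Homo sapiens) for cytotoxicity, read by MTT assay, with a stated time of 3 days; a higher number here means a weaker inhibitor, a lower number a stronger inhibitor:
compound 1 `N#Cc1c(O)nc(SCc2nc3ccccc3[nH]2)nc1-c1ccccc1`: 3.28 nM
compound 2 `N#Cc1c(NN)nc(SCc2nc3ccccc3[nH]2)nc1-c1ccccc1`: 3.9 nM
compound 3 `N#Cc1c(Nc2ccccn2)nc(SCc2nc3ccccc3[nH]2)nc1-c1ccccc1`: 2.55 nM

Compound 3 gives 2.55 nM, which puts it level with the other two compounds. The comparisons are a 1.3-fold lower number from compound 1 to compound 3 (0.11 log units; within the scatter) and a 1.5-fold lower number from compound 2 to compound 3 (0.18 log units; within the scatter), so this small set shows no real separation.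

Compound 4 `N#Cc1c(NC(N)=S)nc(SCc2nc3ccccc3[nH]2)nc1-c1ccccc1` keeps the shared core of compound 3 and changes only the group on the nitrogen: a group of 3 heavy atoms (1 carbon, 1 nitrogen, 1 sulfur; no ring) in place of a group of 6 heavy atoms (5 carbon, 1 nitrogen; one six-membered aromatic ring with 1 hetero atom), on a nitrogen on an aromatic ring. The incoming group has no ring, so a six-membered aromatic ring is lost.

The closest evidence is the change on that same nitrogen, a 1.5-fold lower number from compound 2 to compound 3 (0.18 log units; within the scatter), where pyridin-2-yl replaced amino. Two further changes at the aromatic carbon carrying this substituent, a 1.2-fold higher number from compound 1 to compound 2 (0.08 log units; within the scatter) and a 1.3-fold lower number from compound 1 to compound 3 (0.11 log units; within the scatter), were just as small. All three compounds therefore tolerate quite different groups here without leaving the scatter in this assay. Even so, none of them carries sulfur in this group, so the data cannot rule out a surprise.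

No change beyond the scatter is expected, and the estimated step is a 1.3-fold higher number from compound 3 to compound 4 (0.10 log units; within the scatter). For compound 4 the expected value is 3.2 nM, with an estimated range from 1.5 nM to 7 nM.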

Compound 4, half-maximal inhibitory concentration: 20 nM
The estimate for compound 4 lay 6.3-fold (0.80 log units) below the measured number; the measured number lies above the stated range.
By their numbers in this assay, from the lowest: compounds 3, 1 and 2 (each within the scatter of the next); then compound 4.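

This position is less forgiving than the first three compounds suggested: in this assay, replacing pyridin-2-yl on the nitrogen with the ring-free, sulfur-bearing group gives a 7.8-fold higher number from compound 3 to compound 4 (0.89 log units; beyond the scatter), which makes compound 4 the weakest of the four. Losing the ring cannot be enough on its own to account for this, since compound 2 also has no ring in this group and still stands within the scatter of compound 3, yet the sulfur-bearing group gives a 5.1-fold higher number from compound 2 to compound 4 (0.71 log units; beyond the scatter). The comparison with the hydroxy compound points the same way, with a 6.1-fold higher number from compound 1 to compound 4 (0.79 log units; beyond the scatter), but nothing shown gives a measured reason for the shift.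

Among these compounds, compound 4 is the only compound here with sulfur in this group, so the sulfur atom and the rest of the group cannot be told apart. As far as these compounds go, a urea, with oxygen in place of the sulfur, and an acetyl group on the same nitrogen would be the obvious comparisons, and how either would behave in this assay remains open.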